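A few compounds are considered here, and "the series" means these few. Any claim that something is new, unique, unknown or untested is made for them only; others in the source may bear on it.

Measured so far:
compound 1, `Cc1cc(C)c(NC(=O)N(Cc2ccc(-c3n[nH]c(C)n3)cc2)C2CCCCCC2)c(C)c1` — > 1 mg/kg
compound 2, `Cc1cc(C)c(NC(=O)N(Cc2ccc(-c3ccnn3C)cc2)C2CCCCCC2)c(C)c1` — < 1 mg/kg

In a functional assay on a cell-free system (plasma) with sterol O-acyltransferase, Soat (Rattus norvegicus) as the target (on this read-out higher numbers stand for an effect only at larger amounts of compound and lower numbers for an effect already at smaller amounts), compound 2 gives < 1 mg/kg, which is a limit of the assay and not a number. Compound 1 gives > 1 mg/kg, likewise a limit. Among the measured compounds shown here, the single step measured so far, a number no higher from compound 1 to compound 2 (the limit leaves the size open), therefore shows a direction at most and no readable size; both of its ends rest on limits, as the limit of < 1 mg/kg in this assay, at which 1 of the 2 values shown sits, and the limit of > 1 mg/kg in this assay, at which 1 of the 2 values shown sits, show.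

Compound 3, `Cc1cc(C)c(NC(=O)N(Cc2ccc(-n3ccnn3)cc2)C2CCCCCC2)c(C)c1`, differs from compound 2 in one place: 1H-1,2,3-triazol-1-yl in place of 1-methyl-1H-pyrazol-5-yl on an aromatic carbon. For the measured compounds named here, no measured step covers this exchange. Going by the values given here, the only step known, a number no higher from compound 1 to compound 2 (the limit leaves the size open), replaces a different five-membered ring on the same aromatic carbon, and since its size is not readable it offers no guide to the size or direction of the new change. The expectation for compound 3 is therefore anchored on compound 2 alone. The step that this estimate means, a step that the limit leaves unreadable from compound 2 to compound 3, is expected to lie within the usual scatter. Compound 3 is expected to give 0.7 mg/kg, with a range from 0.2 mg/kg to 3 mg/kg.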

Compound 3, dose for half-maximal effect: > 1 mg/kg
Compound 3 was reported as a limit (the forecaster's own chance of this, stated with the estimate: 60%); at least 1.4-fold (0.15 log units) between middle value and limit.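

Swapping 1-methyl-1H-pyrazol-5-yl for 1H-1,2,3-triazol-1-yl on this aromatic carbon gives, in this assay, a number no lower from compound 2 to compound 3 (the limit leaves the size open); both ends of this step are limits of the assay and not numbers, so it shows a direction only, and it shows that this position does not treat these two five-membered aromatic rings alike. The step between compound 1 and compound 3 cannot be read, as the two limits leave it open. Of the three rings tried here, the two triazolyl rings, 5-methyl-1H-1,2,4-triazol-3-yl and 1H-1,2,3-triazol-1-yl, sit on the same side of the limit and the pyrazolyl ring on the other, with no compound shown going against this: the limit of > 1 mg/kg in this assay, at which 2 of the 3 values shown sit.

As far as these compounds go, how far apart compound 2 and compound 3 really lie stays open, and so does any ranking of the rings by size of effect. From the compounds shown here alone, all three compounds carry a five-membered aromatic ring at this place, so it also stays open how a different kind of group there, such as a carboxylic acid or a primary amine, would read.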